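From trifluoromethyl to 1-methoxy-1-methylethyl

The compounds below may be only part of what the source reports. "The series", "measured", "known", "first", "only" and "open" are said of these compounds alone.

In a physicochemical assay for lipophilicity (a higher number here means a more lipophilic compound, a lower number a more polar compound), compound 1 `C[C@H](NC(=O)c1cc(C(F)(F)F)nn1C)c1nc(-c2ccnc(N3CCCC3)c2)no1` gives 4.2, compound 2 `C[C@H](NC(=O)c1cc(C(F)(F)F)nn1C)c1nc(-c2ccnc(N(C)C)c2)no1` gives 3.9 and compound 3 `C[C@H](NC(=O)c1cc(C(F)(F)F)nn1C)c1nc(-c2ccnc(C(F)(F)F)c2)no1` gives 3.6. Compound 3 cannot be told apart from compound 2 but stands clear of compound 1, as the two steps show: a number 0.30 log units lower from compound 2 to compound 3 (within the scatter) and a number 0.60 log units lower from compound 1 to compound 3 (beyond the scatter). Compound 4 `COC(C)(C)c1cc(-c2noc([C@H](C)NC(=O)c3cc(C(F)(F)F)nn3C)n2)ccn1` carries 1-methoxy-1-methylethyl in place of trifluoromethyl, on an aromatic carbon next to the ring nitrogen: 1-methoxy-1-methylethyl in place of trifluoromethyl on an aromatic carbon. Within the data shown here, those two steps bring trifluoromethyl in, but no measured step brings in the new group, so they offer a rough size and no direction. The expected change is therefore none beyond the scatter, with an estimated a number 0.10 log units lower from compound 3 to compound 4 (within the scatter). For compound 4 the estimated value is 3.5, within a range of 3.1 to 3.9.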

Compound 4, distribution coefficient: 3.8
Compound 4: the middle estimate sits 0.30 log units below what was measured, within the range that was stated.
By their numbers in this assay, from the lowest: compounds 3, 4, 2 and 1 (each within the scatter of the next, the first and the last beyond it).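

On an aromatic carbon next to the ring nitrogen, 1-methoxy-1-methylethyl brings in an oxygen and a hydrogen-bond acceptor, yet this assay cannot separate it from trifluoromethyl or dimethylamino: the steps are a number 0.20 log units higher from compound 3 to compound 4 (within the scatter) and a number 0.10 log units lower from compound 2 to compound 4 (within the scatter). Only pyrrolidin-1-yl remains distinct, with a number 0.40 log units lower from compound 1 to compound 4 (beyond the scatter) as the step. Nothing available explains these differences. On these data alone, it remains open whether a simple methoxy group or a carboxylic acid at this position would also stay within the scatter of compound 4.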